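Pyrrolidinyl for diethylamino on the aniline ring

This account rests on a few compounds, and the source may have more. Where it says the series, first, only, none or still open, it means among the compounds named here.

Measured compounds:
Compound 1, `CCC(=O)Nc1cccc(Oc2nc(Nc3ccc(N4CCCC4)cc3OC)ncc2Cl)c1`: 25.8%
Compound 2, `CCC(=O)Nc1cccc(Oc2nc(Nc3ccc(N(CC)CC)cc3)ncc2Cl)c1`: 54.4%

The two compounds were tested in an assay on isolated protein for inhibition of NUAK family SNF1-like kinase 1 (Homo sapiens), read by ADP-Glo, with a stated time of 60 min, tested at 10 uM, in the presence of a further agent that is not named here; on this read-out higher numbers stand for more inhibition at the one concentration tested (going by the name of the read-out) and lower numbers for less inhibition. In this assay compound 2 gives 54.4%, the higher of the two numbers. Among the compounds with values here, compound 1 gives 25.8%, a value well below that of compound 2 and beyond the scatter, but compound 1 differs from compound 2 in more than one place, so no single step can be drawn from the pair.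

Compound 3, `CCC(=O)Nc1cccc(Oc2nc(Nc3ccc(N4CCCC4)cc3)ncc2Cl)c1`, has not yet been measured. It differs from compound 2 in one place: pyrrolidin-1-yl in place of diethylamino on an aromatic carbon. The change is a swap of one five-atom amine for another on the same aromatic carbon, with the rest of compound 2 kept. Within the data shown here, no measured pair in this set isolates this change, and compound 1 carries the pyrrolidin-1-yl group only together with a further difference. The step from compound 2 to compound 3 is therefore expected to be small, a number 6.4 percentage points lower from compound 2 to compound 3 (within the scatter), with no clear direction beyond the scatter. Compound 3 is estimated to give 48%, between 28% and 68%.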

Compound 3, a percentage reported as inhibition, at one concentration (the size of the read-out at that concentration, not a potency): "not active" (no number reported)
The entry for compound 3 holds no number, and the estimate cannot be compared.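

Within the data shown here, compound 3 is reported as "not active" in this assay with no number, so no step from compound 2 to compound 3 can be read. Nothing shown here bears on this result. The compounds shown leave open how far pyrrolidin-1-yl in place of diethylamino shifts inhibition in this assay.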